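Replacing an amide linker by an aryl ether on the side chain

The compounds below may be only part of what the source reports. "The series", "measured", "known", "first", "only" and "open" are said of these compounds alone.

The shared core, seen in compound 1 `CC(C)=CCC1Cc2c(O)cc(=O)n(CCCO)c2CC1(C)C`, carries a hydroxyl on its aromatic ring; in a functional assay on PANC-1 cells (Homo sapiens) for inhibition, read by MTT assay, with a stated time of 24 h, tested at 10 uM (a lower number here means less inhibition, a higher number more inhibition at the concentration tested (going by the name of the read-out)), compound 1 gives 25.6%. Compound 2 `CC(C)=CCC1Cc2c(OCCCNS(=O)(=O)c3ccc([N+](=O)[O-])cc3)cc(=O)n(CCCO)c2CC1(C)C` extends that oxygen by a chain ending in a sulfonamide, and in this assay compound 2 gives 47.7%. Compound 3 `COc1ccc(C(=O)NCCCOc2cc(=O)n(CCCO)c3c2CC(CC=C(C)C)C(C)(C)C3)cc1` carries a carbonyl in place of the sulfonyl on the chain nitrogen, and in this assay compound 3 gives 55.5%, the highest of the three numbers. The step of a number 7.8 percentage points higher from compound 2 to compound 3 (within the scatter) lies within the scatter, whereas the gap between compound 1 and compound 3 lies beyond it.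

Compound 4 `CC(C)=CCC1Cc2c(OCCCOc3ccc([N+](=O)[O-])cc3)cc(=O)n(CCCO)c2CC1(C)C` differs from compound 3 in one place: 4-nitrophenoxy in place of ((4-methoxyphenyl)carbonyl)amino on a saturated chain carbon, three bonds along the chain from an oxygen on an aromatic ring. Among the measured compounds shown here, the single measured step of a related kind, a number 7.8 percentage points higher from compound 2 to compound 3 (within the scatter), exchanged one aryl group on the chain nitrogen for another and stayed within the scatter. The values of compound 1 and compound 3 show that an aryl-bearing chain on the aromatic oxygen goes with a higher number, and compound 4 keeps such a chain. For the measured compounds named here, no measured step removes the chain nitrogen itself, so the expected step of a number 5.5 percentage points lower from compound 3 to compound 4 (within the scatter) is small, none beyond the scatter. The estimate for compound 4 in this assay is 50%, ranging from 32% to 66%.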

Compound 4, a percentage reported as inhibition, at one concentration (the size of the read-out at that concentration, not a potency): 47.5%
The estimate for compound 4 lay 2.5 percentage points above the measured number, and the stated range covers the measured number.
By their numbers in this assay, from the lowest: compound 1; then compounds 4, 2 and 3 (each within the scatter of the next).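

In this assay, a number 8 percentage points lower from compound 3 to compound 4 (within the scatter) shows that the chain on the aromatic oxygen can lose its ((4-methoxyphenyl)carbonyl)amino end, and with it the chain nitrogen and its hydrogen-bond donor, in favour of 4-nitrophenoxy without a change beyond the scatter. Among the compounds shown here, the earlier step between compound 2 and compound 3 kept that nitrogen and altered only what it carried, so this is the first measured step in which the nitrogen itself goes, and within these compounds it is not required to keep the number in that range. No measurement on hand explains why the exchange leaves the number within the scatter.

The step changes the linking atoms and the substituent on the aryl ring together, so the two contributions cannot be separated, and a 4-methoxyphenoxy group at the same place would be needed to tell them apart. Also open, as far as these compounds go, is whether the aryl ring is needed at all, as a chain ending in a simple amine or a carboxylic acid could show, and how a longer chain would read in this assay.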